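Swapping Furan-2-yl for Tert-Butoxy: Notes on Compound 4

The compounds below may be only part of what the source reports. "The series", "measured", "known", "first", "only" and "open" are said of these compounds alone.

Compound 3 `Cc1cc(-c2ccco2)c(S(C)(=O)=O)cc1C(=O)N=C(N)N` gives 16 nM in a functional assay for inhibition of sodium/hydrogen exchanger (Oryctolagus cuniculus) (on this read-out lower numbers stand for stronger inhibition and higher numbers for weaker inhibition), the lowest number of the three measured. Compound 2 `CCc1cc(Br)c(S(C)(=O)=O)cc1C(=O)N=C(N)N` gives 41 nM and compound 1 `CCc1cc(Cl)c(S(C)(=O)=O)cc1C(=O)N=C(N)N` gives 63 nM, both beyond the scatter from compound 3. Among the compounds with values here, the only measured one-place step, a 1.5-fold lower number from compound 1 to compound 2 (0.19 log units; within the scatter), is a halogen swap and sits within the scatter; it does not cover the change at hand. Compound 4 `Cc1cc(OC(C)(C)C)c(S(C)(=O)=O)cc1C(=O)N=C(N)N` differs from compound 3 by tert-butoxy in place of furan-2-yl on an aromatic carbon. Within the data shown here, no measured pair tests an aromatic ring giving way to a group with no ring, so the expectation rests on compound 3 and the two halogen compounds alone. The number for compound 4 is expected to drift upward, estimated as a 2.5-fold higher number from compound 3 to compound 4 (0.40 log units; beyond the scatter), toward the halogen compounds. Compound 4 is estimated at 40 nM, range 14 nM to 115 nM.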

Compound 4, half-maximal inhibitory concentration: 9.4 nM
Compound 4: middle estimate off by 4.3-fold (0.63 log units), on the high side; the measured number lies below the stated range.
By their numbers in this assay, from the lowest: compounds 4 and 3 (each within the scatter of the next); then compounds 2 and 1 (each within the scatter of the next).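

In this assay tert-butoxy in place of furan-2-yl, on the aromatic carbon ortho to a methylsulfonyl group, gives a 1.7-fold lower number from compound 3 to compound 4 (0.23 log units; within the scatter) and so shows that this position does not depend on an aromatic ring to keep the number of compound 3. The two groups share the same heavy-atom and hydrogen-bond acceptor counts, so the change here is mainly the loss of the ring. Nothing available explains why the two groups read alike. Going by these compounds, whether smaller groups without a ring, such as methoxy, or an amine on this carbon would hold the number stays open. Also open, on these data alone, is how ethyl in place of the methyl group would read alongside tert-butoxy.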